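The source may hold more compounds than are shown below. What is called first, only, known or untested is meant among the compounds shown, and "the series" means these compounds.

Measured so far in a physicochemical assay for solubility, using the shake flask method, in phosphate buffer, with a stated time of 24 h, at 37 degrees C, at pH 6.8; on this read-out higher numbers stand for higher solubility and lower numbers for lower solubility:
- compound 1 `Cc1nc(O)c2c[nH]nc2n1`: 2020 ug/mL
- compound 2 `CCc1nc(O)c2c[nH]nc2n1`: 940 ug/mL

Compound 2 holds the lower of the two numbers, at 940 ug/mL. The next member is compound 3 `CCCc1nc(O)c2c[nH]nc2n1`, which is not yet measured. The change is methyl in place of hydrogen on a saturated chain carbon, two bonds along the chain from an aromatic carbon, in words methyl in place of hydrogen on a saturated chain carbon, two bonds along the chain from an aromatic carbon, or ethyl to propyl.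

Within the data shown here, the one measured step that bears on this is a 2.1-fold lower number from compound 1 to compound 2 (0.33 log units; beyond the scatter), for methyl in place of hydrogen on a saturated chain carbon bound to an aromatic carbon. A single step is thin evidence, but a modest fall of similar size is expected again in this assay. The expected change is a 2.1-fold lower number from compound 2 to compound 3 (0.32 log units; beyond the scatter). For compound 3 the estimate is 450 ug/mL, with an expected range of 220 ug/mL to 850 ug/mL.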

Compound 3, solubility: 2560 ug/mL
Estimate against measurement, compound 3: 5.7-fold (0.76 log units) below; the whole stated range lies below it.
By their numbers in this assay, from the lowest: compound 2; then compounds 1 and 3 (each within the scatter of the next).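

In this assay, methyl in place of hydrogen on a saturated chain carbon bound to an aromatic carbon gave a 2.1-fold lower number from compound 1 to compound 2 (0.33 log units; beyond the scatter) and so does not predict the direction of the same exchange farther out: on a saturated chain carbon, two bonds along the chain from an aromatic carbon, the result is a 2.7-fold higher number from compound 2 to compound 3 (0.44 log units; beyond the scatter) and the sign is reversed. The combined exchange gives a 1.3-fold higher number from compound 1 to compound 3 (0.10 log units; within the scatter) overall, so these three compounds show no steady trend with chain length, and compound 2 alone stands apart. Nothing measured alongside these numbers accounts for the reversal.

From the compounds shown here alone, whether a longer chain such as butyl continues the rise or falls back remains open. Going by these compounds, how a branched isopropyl group, an amine or a carboxylic acid would behave at this position also remains open.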